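The compounds below may be only part of what the source reports. "The series", "measured", "known", "first", "only" and "open" are said of these compounds alone.

Compound 1 `CN(C)S(=O)(=O)c1ccc(F)c(C#Cc2cc(Cl)ccc2OCC(=O)O)c1`: 0.009
Compound 2 `CC(C)S(=O)(=O)c1ccc(Cl)c(C#Cc2cc(Cl)ccc2OCC(=O)O)c1`: "not determined" (no result reported)
Compound 3 `CN(C)S(=O)(=O)c1cncc(C#Cc2cc(Cl)ccc2OCC(=O)O)c1`: 0.033

These results come from an ADME assay on a cell-free system (plasma, Homo sapiens); on this read-out lower numbers stand for a smaller free fraction and higher numbers for a larger free fraction. Going by the values given here, only two of the three compounds have a number. Compound 1, at 0.009, holds the lower of the two. Compound 3 gives 0.033, a higher number by a margin beyond the usual scatter of repeated measurements. Compound 2 has no result to compare.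

The next compound to be measured is compound 4 `Cc1ccc(S(=O)(=O)N(C)C)cc1C#Cc1cc(Cl)ccc1OCC(=O)O`. It keeps the core of compound 1 and makes one change: methyl in place of fluoro on an aromatic carbon. The new group sits para to a dimethylsulfamoyl group.

Among the compounds with values here, no pair of measured compounds differs in one place only, so the data offer no direct guide to the size of this swap. The two groups are counted alike, and the expectation therefore starts from compound 1 at 0.009, with no clear shift in either direction. The expected result is a 1.1-fold lower number from compound 1 to compound 4 (0.05 log units; within the scatter), a step that would stay within the scatter. The estimate for compound 4 is 0.008, with an expected range from 0.004 to 0.016.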

Compound 4, unbound fraction: 0.004
The estimate for compound 4 lay 2.0-fold (0.30 log units) above the measured number; measured number inside the range.
By their numbers in this assay, from the lowest: compound 4; then compound 1; then compound 3.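

In this assay, going by these compounds alone, methyl in place of fluoro on this aromatic carbon, ortho to a large group and para to a dimethylsulfamoyl group, gives a 2.3-fold lower number from compound 1 to compound 4 (0.35 log units; beyond the scatter) and so provides the first step in this set that can be traced to a single place. The position is therefore not silent: the free fraction responds to this swap even though the two groups count the same number of heavy atoms, and neither brings a hydrogen-bond donor, a hydrogen-bond acceptor or a net charge. No measurement at hand bears on the reason for this shift.

This single pair gives the size of one swap at one position and sets no rule for other groups or other places on the molecule. Going by these compounds, it remains open whether a trifluoromethyl, a methoxy or a nitrile on this same aromatic carbon would move the free fraction further in the same direction or back the other way, and whether the methyl-for-fluoro swap would give a similar step if a different group stood in place of the dimethylsulfamoyl group.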